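This account rests on a few compounds, and the source may have more. Where it says the series, first, only, none or still open, it means among the compounds named here.

Compound 1 `N#Cc1ccc(C2OCC(C/C=C\CCC(=O)O)C(c3cccnc3)O2)cc1` is a pyridin-3-yl-bearing acetal acid that carries a 4-cyanophenyl group. Within the data shown here, in a functional assay for inhibition, with Homo sapiens as the target (on this read-out lower numbers stand for tighter binding and higher numbers for weaker binding), compound 1 gives 1290 nM, the lowest of the two numbers known here. Among the measured compounds shown here, its only measured neighbour, compound 2 `O=C(O)CC/C=C\CC1COC(c2ccsc2)OC1c1cccnc1`, gives 1580 nM in this assay, and the step of a 1.2-fold higher number from compound 1 to compound 2 (0.09 log units; within the scatter) shows that exchanging the 4-cyanophenyl group for a five-membered heteroaryl left the read-out unchanged.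

Compound 3 `O=C(O)CC/C=C\CC1COC(c2ccco2)OC1c1cccnc1` is the unmeasured analogue. The change from compound 1 to compound 3 is furan-2-yl in place of 4-cyanophenyl on a saturated ring carbon

For the measured compounds named here, this change is of the same kind as the one from compound 1 to compound 2, so the expectation for this assay is a step of a 1.3-fold higher number from compound 1 to compound 3 (0.12 log units; within the scatter), with no movement beyond the scatter. Compound 3 is therefore expected to give about 1700 nM in this assay, most likely between 800 nM and 3600 nM.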

Compound 3, dissociation constant: 1260 nM
Beside the measured number, compound 3's estimate is 1.3-fold (0.13 log units) above it, and the stated range covers the measured number.
By their numbers in this assay, from the lowest: compounds 3, 1 and 2 (each within the scatter of the next).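

In this assay, the step of a 1.0-fold lower number from compound 1 to compound 3 (0.01 log units; within the scatter) shows that this saturated ring carbon, between two ring oxygen atoms, accepts furan-2-yl in place of 4-cyanophenyl with no movement beyond the scatter, although the 8 heavy atoms of the leaving group give way to only 5. The step of a 1.3-fold lower number from compound 2 to compound 3 (0.10 log units; within the scatter) adds that furan-2-yl and thiophen-3-yl are not told apart in this read-out, so the three groups now seen at this carbon all lie within the scatter of one another. The compounds shown all carry an aromatic ring at this carbon, so they leave open how an open-chain alkyl group, an amine or a carboxylic acid would read there. No measured evidence bearing on this result is available here.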